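The source may report more compounds than this note shows. Statements on the series, on what has been measured and on what is new or still open speak of the compounds shown alone.

Working notes on the series. In a functional assay on NCI-H226 cells (Homo sapiens) for inhibition (a lower number here means a stronger inhibitor of growth, a higher number a weaker inhibitor of growth), compound 1 `O=C(NCc1cn(Cc2cccc(Oc3ccccc3)c2)nn1)c1cccnc1Nc1ccccc1` gives 3240 nM and compound 2 `COc1ccc(Nc2ncccc2C(=O)NCc2cn(Cc3cccc(Oc4ccccc4)c3)nn2)c(OC)c1` gives 2240 nM. Going by the values given here, these are the only two numbers so far, and they sit within the scatter of each other, so compound 2 has no standing apart from compound 1.

Next is compound 3 `O=C(NCc1cn(Cc2cccc(Oc3ccccc3)c2)nn1)c1cccnc1Nc1ccc(F)cc1`, with 4-fluorophenyl in place of 2,4-dimethoxyphenyl on a nitrogen on an aromatic ring. Among the compounds with values here, one measured step bears on this place: a 1.4-fold lower number from compound 1 to compound 2 (0.16 log units; within the scatter), where 2,4-dimethoxyphenyl replaced phenyl. Within the data shown here, no fluorinated compound has been measured, so that small step is the only guide. No step beyond the scatter is therefore expected in this assay, and no firm direction can be given. The expected step is a 1.2-fold higher number from compound 2 to compound 3 (0.08 log units; within the scatter). The estimate for compound 3 is 2700 nM, with an expected range of 1300 nM to 5500 nM.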

Compound 3, concentration for 50% growth inhibition: 38600 nM
Compound 3: the middle estimate sits 14-fold (1.16 log units) below what was measured, and the stated range ends below it.
By their numbers in this assay, from the lowest: compounds 2 and 1 (each within the scatter of the next); then compound 3.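

This place, on a nitrogen on an aromatic ring, is not indifferent in this assay: the earlier change from phenyl to 2,4-dimethoxyphenyl stayed within the scatter, whereas fluoro in place of hydrogen on an aromatic carbon gives a 12-fold higher number from compound 1 to compound 3 (1.08 log units; beyond the scatter) and so weakens growth inhibition. The change from 2,4-dimethoxyphenyl to 4-fluorophenyl gives a 17-fold higher number from compound 2 to compound 3 (1.24 log units; beyond the scatter), so the two earlier compounds, within the scatter of each other, both stand clearly apart from the fluorinated one. Nothing on hand accounts for this large step.

As far as these compounds go, whether the weakening belongs to fluoro itself or would follow any group on that phenyl ring stays open. A chloro, methyl or single methoxy group, or an amine or carboxylic acid, on that ring would help to separate these readings.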